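The compounds below may be only part of what the source reports. "The series", "measured", "known", "first", "only" and "open" are said of these compounds alone.

Compound 3 `Fc1ccc(-c2nn3c(NC4CCCC4)cccc3c2-c2ccc(F)nc2)cc1` shares its core with compound 1 `Fc1ccc(-c2nn3c(NC4CCCC4)cccc3c2-c2ccnc(F)c2)cc1` and compound 2 `Fc1ccc(-c2nn3c(NC4CCCC4)cccc3c2-c2ccc3[nH]ccc3c2)cc1`. In an ADME assay on Vero cells (Chlorocebus sabaeus) for cytotoxicity (a lower number here means that less compound is tolerated, a higher number that more compound is tolerated), compound 2 gives 20000 nM, whereas for compound 3 the result in this assay is "not determined" (no result reported), and for compound 1 it is likewise "not determined" (no result reported). Compound 3 therefore stands without a number of its own in this assay. Compound 4 `Fc1ccc(-c2nn3c(NC4CCCC4)cccc3c2-c2cn[nH]c2)cc1` differs from compound 3 in one place: 1H-pyrazol-4-yl in place of 6-fluoropyridin-3-yl on an aromatic carbon. Going by the values given here, with no measured step to lean on, the change from compound 3 to compound 4 is expected to move this assay by no more than the usual scatter, in no particular direction. Compound 4 is expected to give about 30000 nM in this assay, with a likely range from 10000 nM to 100000 nM.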

Compound 4, half-maximal cytotoxic concentration: 10000 nM
For compound 4 the middle estimate is 3.0-fold (0.48 log units) above the measured one; measured number inside the range.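

In this assay the position gains its first readable step, a 2.0-fold lower number from compound 2 to compound 4 (0.30 log units; within the scatter), so exchanging these two groups on this aromatic carbon leaves the cytotoxic concentration within the scatter. The change from 6-fluoropyridin-3-yl to 1H-pyrazol-4-yl itself cannot be read, as compound 3 has no number of its own. No measurement shown here accounts for the result. The compounds shown leave open whether a carboxylic acid or an aminomethyl group on this aromatic carbon would move the value beyond the scatter.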